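Changing the Terminal Group on a Shared Core

A few compounds are considered here, and "the series" means these few. Any claim that something is new, unique, unknown or untested is made for them only; others in the source may bear on it.

Of the compounds shown here, three built on one shared core have been measured in an ADME assay on L6 cells (Rattus norvegicus) for cytotoxicity, read by resazurin assay, with a stated time of 70 h; on this read-out higher numbers stand for weaker inhibition and lower numbers for stronger inhibition. Compound 1 `COc1cc(NC(C)CCCNC(=O)/C=C/c2ccccc2)c2ncccc2c1` gives 18500 nM. Compound 3 `COc1cc(NC(C)CCCNC(=O)NNC(=O)/C(C)=C/c2ccccc2)c2ncccc2c1` gives 36500 nM, the highest of the two numbers; its nearest neighbour is compound 1, and the two values lie within the scatter of each other. Compound 2 `COc1ccc(/C(=N/NC(=O)NCCCC(C)Nc2cc(OC)cc3cccnc23)c2ccccc2)cc1` is reported only as a limit of this assay, > 195000 nM. This limit is the limit of > 195000 nM in this assay, at which 1 of the 3 values shown sits. Compound 4 `COc1cc(NC(C)CCCNC(=O)NNC(=O)Nc2cccc(C(F)(F)F)c2)c2ncccc2c1` differs from compound 3 at a single point: (3-(trifluoromethyl)phenyl)amino in place of 1-methyl-2-phenylethenyl on a carbonyl carbon. Among the measured compounds shown here, no measured pair shows a change of this kind, so no step size is known for it. The step of a 1.1-fold higher number from compound 3 to compound 4 (0.04 log units; within the scatter) is expected to stay within the scatter. Compound 4 is estimated at 40000 nM, with a range from 12000 nM to 150000 nM.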

Compound 4, half-maximal inhibitory concentration: 32100 nM
For compound 4 the middle estimate is 1.2-fold (0.10 log units) above the measured one, and the stated range covers the measured number.
By their numbers in this assay, from the lowest: compounds 1, 4 and 3 (each within the scatter of the next). At a limit, above all of these: compound 2.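

Among the compounds shown here, replacing 1-methyl-2-phenylethenyl with (3-(trifluoromethyl)phenyl)amino on a carbonyl carbon gives the first measured step at this position in this assay, a 1.1-fold lower number from compound 3 to compound 4 (0.06 log units; within the scatter). The position therefore accepts a group with one more hydrogen-bond donor and trifluoromethyl on its six-membered aromatic ring while the values remain within the scatter. Nothing measured here bears on why these values lie so close. Going by these compounds, it remains open whether a group without an aromatic ring, such as an amine or a carboxylic acid, would also stay within the scatter at this carbonyl carbon.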